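The compounds below may be only part of what the source reports. "The series", "measured", "known", "first", "only" and "open" are said of these compounds alone.

Measured compounds in an assay on HEK293 cells for displacement of a labelled ligand from Melanocortin receptor 4 (Homo sapiens); a lower number here means a stronger inhibitor, a higher number a weaker inhibitor:
- compound 1, `CC(C)C[C@H](N)c1cc(C(F)(F)F)ccc1N1CCN(C(=O)C(C)Cc2ccc(Cl)cc2)CC1`: 47 nM
- compound 2, `CC(C)C[C@H](N)c1cc(C(F)(F)F)ccc1N1CCN(C(=O)CNc2ccccc2)CC1`: 3600 nM

Compound 2 stands highest of the two numbers in this assay; its nearest neighbour is compound 1, and the step of a 77-fold higher number from compound 1 to compound 2 (1.88 log units; beyond the scatter) is large and beyond the scatter. That step replaced 1-(4-chlorobenzyl)ethyl with anilinomethyl on the carbonyl carbon.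

Compound 3, `Cc1ccc(CC(C)C(=O)N2CCN(c3ccc(C(F)(F)F)cc3[C@@H](N)CC(C)C)CC2)cc1C`, is not yet measured. Among the compounds with values here, it differs from compound 2 by 1-(3,4-dimethylbenzyl)ethyl in place of anilinomethyl on a carbonyl carbon, which is essentially the reverse of the only step available: an anilinomethyl group gives way to a branched benzyl-bearing group of the kind seen in compound 1, here with two methyl groups on the ring in place of the chlorine. Given compound 1 at 47 nM and the step of a 77-fold higher number from compound 1 to compound 2 (1.88 log units; beyond the scatter), compound 3 is expected to move a long way back down, with the step of a 60-fold lower number from compound 2 to compound 3 (1.78 log units; beyond the scatter) estimated as large. Compound 3 is expected at 60 nM, within 15 nM to 250 nM.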

Compound 3, inhibition constant: 240 nM
Compound 3: middle estimate off by 4.0-fold (0.60 log units), on the low side; the range from low to high includes it.
By their numbers in this assay, from the lowest: compound 1; then compound 3; then compound 2.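

In this assay, the 1-(3,4-dimethylbenzyl)ethyl group on the carbonyl carbon recovers much of the ground lost with anilinomethyl, with a 15-fold lower number from compound 2 to compound 3 (1.18 log units; beyond the scatter) on this exchange, so a low number at this position does not require the chlorine of compound 1. The aryl substitution still matters: 3,4-dimethylphenyl in place of 4-chlorophenyl gives a 5.1-fold higher number from compound 1 to compound 3 (0.71 log units; beyond the scatter) as a modest step, and compound 1 remains the lowest of the three. No measured evidence accounts for the size of either step.

Still open, as far as these compounds go, is whether the rise from compound 1 to compound 3 follows the loss of chlorine or the added ring methyl, which a 4-methylphenyl or 3,4-dichlorophenyl group would separate. Also open, from the compounds shown here alone, is what a plain benzyl group, without the chain methyl, would give at this carbonyl carbon.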